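The source may report more compounds than this note shows. Statements on the series, on what has been measured and on what is new or still open speak of the compounds shown alone.

Of the compounds shown here, three sharing one core have been tested in a functional assay on A498 cells (Homo sapiens) for inhibition, read by sulforhodamine B assay, with a stated time of 48 h; a lower number here means a stronger inhibitor of growth, a higher number a weaker inhibitor of growth. Compound 1 `COc1cc(-c2nn(-c3cccc(NC(=O)c4cccc(C(F)(F)F)c4)c3)cc2-c2ccncc2)ccc1Cl` gives 2780 nM. Compound 2 `COc1cc(-c2nn(-c3cccc(NC(=O)Nc4ccc(Cl)c(Cl)c4)c3)cc2-c2ccncc2)ccc1Cl` gives 4590 nM. Compound 3 `COc1cc(-c2nn(-c3cccc(NC(=O)Nc4ccc(Cl)c(C(F)(F)F)c4)c3)cc2-c2ccncc2)ccc1Cl` gives 6970 nM, the highest of the three numbers; its gap to compound 2 lies within the scatter, while the step of a 2.5-fold higher number from compound 1 to compound 3 (0.40 log units; beyond the scatter) lies beyond it. Compound 4 `COc1cc(-c2nn(-c3cccc(NC(=O)c4ccccc4)c3)cc2-c2ccncc2)ccc1Cl` differs from compound 3 by phenyl in place of (4-chloro-3-(trifluoromethyl)phenyl)amino on a carbonyl carbon, which brings the carbonyl back to a directly attached aryl as in compound 1, now without the trifluoromethyl. Within the data shown here, the steps of a 1.7-fold higher number from compound 1 to compound 2 (0.22 log units; within the scatter) and a 1.5-fold higher number from compound 2 to compound 3 (0.18 log units; within the scatter) both fall within the scatter, so only the step toward compound 1 is beyond it. A modest move toward lower numbers is therefore expected, and compound 4 is estimated to show a 2.0-fold lower number from compound 3 to compound 4 (0.30 log units; within the scatter). Compound 4 is thus expected near 3500 nM, within 1500 nM to 8000 nM.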

Compound 4, concentration for total growth inhibition: 3140 nM
Compound 4: the middle estimate sits 1.1-fold (0.05 log units) above what was measured, and the stated range covers the measured number.
By their numbers in this assay, from the lowest: compounds 1, 4, 2 and 3 (each within the scatter of the next, the first and the last beyond it).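

Putting plain phenyl on the carbonyl carbon in place of (4-chloro-3-(trifluoromethyl)phenyl)amino gives a 2.2-fold lower number from compound 3 to compound 4 (0.35 log units; beyond the scatter), whereas the same exchange for (3,4-dichlorophenyl)amino gives a 1.5-fold lower number from compound 2 to compound 4 (0.16 log units; within the scatter), so only the first step clears the scatter. Hydrogen in place of trifluoromethyl gives a 1.1-fold higher number from compound 1 to compound 4 (0.05 log units; within the scatter), so among these compounds that trifluoromethyl is not needed to reach the number of compound 1. No evidence is available to explain these steps. Still open, going by these compounds, is how a methyl or cyclohexyl group on this carbonyl carbon would read, and whether a methoxy or amine on the phenyl would shift the number.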